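Hydroxy for fluoro on the sulfonamide aryl ring

The source may hold more compounds than are shown below. What is called first, only, known or untested is meant among the compounds shown, and "the series" means these compounds.

Measured compounds:
compound 1 `O=S(=O)(Nc1ccc(-c2nc3cc(NS(=O)(=O)c4ccccc4O)ccc3o2)cc1)c1ccccc1O` 18000 nM
compound 2 `O=S(=O)(Nc1ccc(-c2nc3ccccc3o2)cc1)c1ccccc1F` > 100000 nM

In an assay on cells for inhibition of HSP60/HSP10 (Homo sapiens), with a stated time of 60 min (on this read-out higher numbers stand for weaker inhibition and lower numbers for stronger inhibition), compound 1 gives 18000 nM. Compound 2 gives only a limit in this assay, > 100000 nM, so no number for it is known; it sits at the limit of > 100000 nM in this assay, at which 1 of the 2 values shown sits. Compound 3 `O=S(=O)(Nc1ccc(-c2nc3ccccc3o2)cc1)c1ccccc1O` is not yet measured. It differs from compound 2 by hydroxy in place of fluoro on an aromatic carbon. Going by the values given here, with compound 2 at a limit no step between measured compounds can be computed, so the size of the change in this assay is open. The expectation for compound 3 is a move toward stronger inhibition, because compound 1, which carries the hydroxy on its sulfonamide aryl rings, gives 18000 nM. The estimate for compound 3 in this assay is 50000 nM, in the range 15000 nM to 200000 nM, which means an expected step of an at least 2.0-fold lower number from compound 2 to compound 3 (0.30 log units; that floor lies within the scatter). A limit rather than a number remains quite possible for compound 3.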

Compound 3, half-maximal inhibitory concentration: > 100000 nM
Compound 3 was reported as a limit; the forecaster's own chance of this, stated with the estimate: 40%; at least 2.0-fold (0.30 log units) between middle value and limit.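

In this assay, the 2-hydroxyphenyl group on the sulfonamide does not by itself give a readable value on the unsubstituted core: compound 3, like compound 2, is reported only as a limit. The step that can be read runs along a different change, hydrogen in place of ((2-hydroxyphenyl)sulfonyl)amino on an aromatic carbon, and it is an at least 5.5-fold higher number from compound 1 to compound 3 (0.74 log units; beyond the scatter), so within this pair the readable value of compound 1 depends on that second group. The size of the change from 2-fluorophenyl to 2-hydroxyphenyl cannot be read, because both compounds sit at a limit: the limit of > 100000 nM in this assay, at which 2 of the 3 values shown sit.

Going by these compounds, whether the hydroxy contributes once the ((2-hydroxyphenyl)sulfonyl)amino group is present remains open. Also open, on these data alone, is whether a simpler group at that carbon, such as an amine or a carboxylic acid, would keep any of the value of compound 1.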